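A few compounds are considered here, and "the series" means these few. Any claim that something is new, unique, unknown or untested is made for them only; others in the source may bear on it.

Measured compounds in a functional assay on MCF7 cells (Homo sapiens) for antiproliferative activity, read by MTT assay, with a stated time of 72 h; on this read-out higher numbers stand for weaker inhibition and lower numbers for stronger inhibition:

compound 1, `CCCSc1nc(N/N=C/c2ccc(Cl)cc2)c2nnn(Cc3ccccc3)c2n1`: > 64000 nM
compound 2, `C/C(=N\Nc1nc(SCc2ccccc2)nc2c1nnn2Cc1ccccc1)c1ccccc1O`: 950 nM
compound 3, `CCCSc1nc(N/N=C(\C)c2ccccc2O)c2nnn(Cc3ccc(Br)cc3)c2n1`: 15600 nM

For the measured compounds named here, the value for compound 1 is a limit of this assay and not a number; compound 1 is the one compound of the three that sits at the limit of > 64000 nM in this assay, at which 1 of the 3 values shown sits. Going by the values given here, compound 2 and compound 3 each return a number in this assay, and no step between any pair of the three measured compounds is available, so what the numbers show is only that compound 1 has not been resolved, while compound 2 and compound 3 have.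

Compound 4, `CCCSc1nc(N/N=C/c2ccc([N+](=O)[O-])cc2)c2nnn(Cc3ccccc3)c2n1`, is not yet measured. It differs from compound 1 in one place: nitro in place of chloro on an aromatic carbon. The shared core, the propylsulfanyl group and the benzyl group of compound 1 are kept.

With compound 1 at a limit, the step from compound 1 to compound 4 can be expected only as a step from that limit. The expectation is a step of an at least 1.0-fold lower number from compound 1 to compound 4 (0.02 log units; that floor lies within the scatter), that is, none beyond the scatter: the exchange of one small substituent for another on the distal ring is not expected to move the number far. The estimate for compound 4 in this assay is 60000 nM, with a range from 15000 nM to 200000 nM, and a real chance that this assay again reports only a limit.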

Compound 4, half-maximal inhibitory concentration: 11000 nM
For compound 4 the middle estimate is 5.5-fold (0.74 log units) above the measured one; measured number below the stated range.
By their numbers in this assay, from the lowest: compound 2; then compounds 4 and 3 (each within the scatter of the next). At a limit, above all of these: compound 1.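

In this assay, for the compounds shown here, the change from 4-chlorophenyl to 4-nitrophenyl, with the shared core, the propylsulfanyl group and the benzyl group kept, gives an at least 5.8-fold lower number from compound 1 to compound 4 (0.76 log units; beyond the scatter), the only step that can be read so far, and it shows that an exchange at this one place on the aromatic ring is enough to take the series from an unresolved result to a number. Compound 1 gives > 64000 nM, which is a limit of the assay and not a number. The step is therefore a floor on the change, and its full size stays unknown: the limit of > 64000 nM in this assay, at which 1 of the 4 values shown sits.

Open is how an amine or a carboxylic acid at this place would compare with chloro and nitro, as the compounds shown give only these two groups here. Going by these compounds alone, also open is whether the same exchange would keep its direction with a longer chain in place of the propylsulfanyl group: compound 2 and compound 3 differ from compound 4 in more than one place, and no step to either can be read.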